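Swapping 2,5-dimethoxyphenyl for 4-bromophenyl in compound 3

The compounds below may be only part of what the source reports. "The series", "measured", "known", "first", "only" and "open" are said of these compounds alone.

Measured in a functional assay on SW480 cells (Homo sapiens) for antiproliferative activity, read by sulforhodamine B assay, with a stated time of 48 h; on this read-out lower numbers stand for stronger inhibition and higher numbers for weaker inhibition:
compound 1 `COc1ccc(/C=C/C(=O)c2ccccc2-c2ccc(OC)c(OC)c2)cc1`: 890 nM
compound 2 `COc1ccc(/C=C/C(=O)c2ccccc2-c2ccc(OC)c(OC)c2)cc1OC`: 7600 nM
compound 3 `COc1ccc(OC)c(/C=C/C(=O)c2ccccc2-c2ccc(OC)c(OC)c2)c1`: 5200 nM

Compound 3 gives 5200 nM, a number that stands well above that of compound 1, while a 1.5-fold lower number from compound 2 to compound 3 (0.16 log units; within the scatter) separates it from compound 2. Compound 4 `COc1ccc(-c2ccccc2C(=O)/C=C/c2ccc(Br)cc2)cc1OC` carries one change: 4-bromophenyl in place of 2,5-dimethoxyphenyl on a double-bonded chain carbon bound to a double-bonded chain carbon. Going by the values given here, the closest precedent is a 5.8-fold higher number from compound 1 to compound 3 (0.77 log units; beyond the scatter), where 2,5-dimethoxyphenyl replaced 4-methoxyphenyl at this same place, and an 8.5-fold higher number from compound 1 to compound 2 (0.93 log units; beyond the scatter) runs the same way. Among the compounds with values here, no bromine-bearing compound has been measured, so this precedent is only partial. A modest move to a lower number is therefore expected in this assay, with a 3.5-fold lower number from compound 3 to compound 4 (0.54 log units; beyond the scatter) as the estimate. The estimate for compound 4 is 1500 nM, with an expected range of 450 nM to 5000 nM.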

Compound 4, half-maximal inhibitory concentration: 6500 nM
Compound 4: the middle estimate sits 4.3-fold (0.64 log units) below what was measured; measured number above the stated range.
By their numbers in this assay, from the lowest: compound 1; then compounds 3, 4 and 2 (each within the scatter of the next).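

In this assay, the 4-bromophenyl group on a double-bonded chain carbon bound to a double-bonded chain carbon gives no separation from either dimethoxyphenyl group (a 1.3-fold higher number from compound 3 to compound 4 (0.10 log units; within the scatter)) (a 1.2-fold lower number from compound 2 to compound 4 (0.07 log units; within the scatter)). Bromo in place of methoxy on the aromatic carbon of compound 1 gives a step beyond the scatter (a 7.3-fold higher number from compound 1 to compound 4 (0.86 log units; beyond the scatter)), so at this place a single methoxy is set apart from bromo as well as from a second methoxy. No measured data explain this result.

Still open, as far as these compounds go, is whether 4-chlorophenyl or 4-ethoxyphenyl would read with compound 1 or with compound 4. From the compounds shown here alone, a 4-aminophenyl group at this place is equally open.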